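The source may report more compounds than this note shows. Statements on the series, on what has been measured and on what is new or still open speak of the compounds shown alone.

In a functional assay on HepG2 cells (Homo sapiens) for cytotoxicity, read by MTT assay, with a stated time of 24 h (on this read-out lower numbers stand for stronger inhibition and higher numbers for weaker inhibition), compound 1 (`COc1cc(/C=C2\CN(C)C/C(=C\c3ccccc3F)C2=O)cc(OC)c1`) gives 1240 nM. Compound 2 (`COc1cc(/C=C2\CN(C)C/C(=C\c3ccccc3F)C2=O)cc(OC)c1OC`) gives 670 nM, which is close to it, while compound 3 (`CN1C/C(=C\c2ccc(C(C)(C)C)cc2)C(=O)/C(=C/c2ccccc2F)C1`) gives 9120 nM, a clearly higher number than the other two. Compound 1 therefore sits at the lower end of this small set, alongside compound 2.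

Compound 4 (`COc1cc(/C=C2\CN(C)C/C(=C\c3ccc(Cl)cc3Cl)C2=O)cc(OC)c1`) differs from compound 1 in one place: 2,4-dichlorophenyl in place of 2-fluorophenyl on a double-bonded chain carbon bound to a double-bonded ring carbon. Going by the values given here, the only measured step, a 1.9-fold lower number from compound 1 to compound 2 (0.27 log units; within the scatter), swaps a hydrogen for a methoxy elsewhere in the molecule and leaves the 2-fluorophenyl group in place. Among the compounds with values here, compound 3 keeps that group too, so no measured compound shows what replacing it does. With no direct evidence for a shift in either direction, no step beyond the scatter is expected in this assay. The estimated change is a 1.2-fold lower number from compound 1 to compound 4 (0.09 log units; within the scatter). The expected value for compound 4 is 1000 nM, with an estimated range of 350 nM to 3000 nM.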

Compound 4, half-maximal inhibitory concentration: 6250 nM
The estimate for compound 4 lay 6.3-fold (0.80 log units) below the measured number; the measured number lies above the stated range.
By their numbers in this assay, from the lowest: compounds 2 and 1 (each within the scatter of the next); then compounds 4 and 3 (each within the scatter of the next).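

In this assay, the group on the double-bonded chain carbon bound to a double-bonded ring carbon proves able to move the number: 2,4-dichlorophenyl in place of 2-fluorophenyl gives a 5.0-fold higher number from compound 1 to compound 4 (0.70 log units; beyond the scatter). Going by these compounds alone, compounds 1, 2 and 3 all carry 2-fluorophenyl at this place, so they could not show this sensitivity, and this is the first measured sign that the change costs activity in these cells. No available evidence accounts for the rise.

This single step removes the fluorine and brings in both chlorines at once, so it cannot tell which part of the change matters. As far as these compounds go, how this place would respond to a plain phenyl, or to a phenyl carrying an amine or a carboxylic acid, remains open.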